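The source may hold more compounds than are shown below. What is called first, only, known or untested is meant among the compounds shown, and "the series" means these compounds.

Compound 1 `O=C(CCc1cccc2c1B(O)OC2)Nc1ccc(Cl)cc1` and compound 2 `O=C(CCc1cccc2c1B(O)OC2)Nc1cccc(-c2cccc(F)c2)c1` share one core and differ only in the aromatic group carried on the amide nitrogen. Both were tested in an ADME assay on WI-38 cells (Homo sapiens) for cytotoxicity, read by MTT assay, with a stated time of 72 h; a lower number here means a stronger inhibitor, a higher number a weaker inhibitor. For compound 1 the result is a limit of the assay, > 100000 nM, rather than a number. Within the data shown here, compound 2 gives 37000 nM, the only true number of the two, which marks it as a weak inhibitor here. The other value is the limit of > 100000 nM in this assay, at which 1 of the 2 values shown sits. Compound 3 `N#Cc1ccc(-c2cccc(NC(=O)CCc3cccc4c3B(O)OC4)c2)cc1` has not yet been measured. It differs from compound 2 in one place: 4-cyanophenyl in place of 3-fluorophenyl on an aromatic carbon. Among the measured compounds shown here, no step between two measured compounds is available to guide the expectation, so the estimate rests on compound 2 alone. The step of a 1.1-fold higher number from compound 2 to compound 3 (0.03 log units; within the scatter) is expected to be small, with no clear direction beyond the usual scatter. Compound 3 is therefore estimated at 40000 nM in this assay, with a range from 15000 nM to 100000 nM.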

Compound 3, half-maximal inhibitory concentration: 12000 nM
For compound 3 the middle estimate is 3.3-fold (0.52 log units) above the measured one; the measured number lies below the stated range.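

Replacing 3-fluorophenyl with 4-cyanophenyl gives a 3.1-fold lower number from compound 2 to compound 3 (0.49 log units; beyond the scatter) in this assay. Among these compounds, this is the first single change that can be read as a step, and it shows that the group at this place, meta to a large group, can move the number beyond the usual scatter, although compound 3 at 12000 nM still needs a high concentration to register in this assay. The series remains thin in true numbers: the limit of > 100000 nM in this assay, at which 1 of the 3 values shown sits.

This one step changes both the substituent on the outer ring and where it sits, so the effect of the nitrile cannot be separated from that of its place; 3-cyanophenyl and 4-fluorophenyl would be the groups to tell these apart. Going by these compounds, how an amine or a carboxylic acid on that ring would behave also remains open.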